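Hydroxy Removal on a Shared Core: Expected Lipophilicity Shift

The compounds below may be only part of what the source reports. "The series", "measured", "known", "first", "only" and "open" are said of these compounds alone.

Measured so far in a physicochemical assay for lipophilicity, read by HPLC, measured as octanol-water partition, at pH 7.4; on this read-out higher numbers stand for higher lipophilicity and lower numbers for lower lipophilicity:
compound 1 `c1ccc2c3c(ccc2c1)CCC1(CCN(CCC2CCCCC2)CC1)O3` gives 4.74
compound 2 `OC1CC2(CCNCC2)Oc2c1ccc1ccccc21` gives 2.46
compound 3 `CCN1CCC2(CC1)CC(O)c1ccc3ccccc3c1O2` gives 1.88

Compound 3 stands lowest of the three numbers. Within the data shown here, its nearest neighbour is compound 2, and the only one-change step among the measured compounds runs between them: a number 0.58 log units lower from compound 2 to compound 3 (beyond the scatter). Compound 1 lies far higher than both, but it differs from them in more than one place, so its value shows only where a very different member of the series sits.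

Compound 4 `CCN1CCC2(CCc3ccc4ccccc4c3O2)CC1` is the unmeasured compound. It differs from compound 3 in one place: hydrogen in place of hydroxy on a saturated ring carbon. Among the measured compounds shown here, no measured step bears on this change; the single step known, from an ethyl in place of hydrogen on the amine nitrogen, says nothing about a hydroxy leaving a saturated ring carbon. What the structures show is that compound 4 lacks the hydrogen-bond donor and acceptor that compound 3 carries, and a change of that kind is expected to move this assay upward, well beyond the scatter. The estimated step is a number 1.12 log units higher from compound 3 to compound 4 (beyond the scatter). Compound 4 is therefore expected to give about 3, within a range from 2.4 to 3.6.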

Compound 4, distribution coefficient: 2.88
Compound 4: the middle estimate sits 0.12 log units above what was measured; low and high end bracket the measured number.
By their numbers in this assay, from the lowest: compound 3; then compound 2; then compound 4; then compound 1.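

In this assay, among these compounds, replacing hydroxy with hydrogen on this saturated ring carbon gives a number 1.00 log units higher from compound 3 to compound 4 (beyond the scatter) and provides the first reading of a change at this position, two ring bonds from the ring atom that bears two fused rings and three ring bonds from the ring oxygen. Compound 4 also connects compound 1 to the other compounds by a single change, hydrogen in place of cyclohexyl on a saturated chain carbon, two bonds along the chain from an amine nitrogen in a ring: a number 1.86 log units lower from compound 1 to compound 4 (beyond the scatter) is a larger move than the one seen on removing hydroxy. Nothing measured here accounts for the size of either step.

The compounds shown carry only hydroxy or hydrogen at this ring carbon, so where a methoxy group or an amine there would place the number remains open. From the compounds shown here alone, it is also open whether removing hydroxy gives a step of similar size when the amine nitrogen carries hydrogen, as in compound 2, or the longer chain of compound 1.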